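This account rests on a few compounds, and the source may have more. Where it says the series, first, only, none or still open, it means among the compounds named here.

Of the compounds shown here, two of a shared core have been measured in a functional assay, with a stated time of 6 min; a lower number here means a stronger inhibitor, a higher number a weaker inhibitor. Compound 1 `Fc1cccc(NCn2nc(-c3ccc4c(c3)OCCO4)oc2=S)c1` gives 6620 nM, and compound 2 `FC(F)(F)c1ccccc1NCn1nc(-c2ccc3c(c2)OCCO3)oc1=S` gives 9220 nM. For the measured compounds named here, of these two numbers, the one for compound 2 is the larger as recorded, yet its gap to compound 1 is within the scatter, so the two compounds cannot be told apart on this evidence. Both are weak inhibitors in this assay .

The next compound, compound 3 `COc1ccccc1NCn1nc(-c2ccc3c(c2)OCCO3)oc1=S`, differs from compound 2 in a single place: methoxy in place of trifluoromethyl on an aromatic carbon. The change sits on an aromatic carbon of a six-membered aromatic ring of carbon only, ortho to a large group. Going by the values given here, no step between measured compounds has been recorded, so there is nothing to calibrate the effect of this exchange; the two measured values simply show that a fluorine-bearing ring and a trifluoromethyl-bearing ring give numbers of the same order.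

The step is expected to be small, a 1.5-fold lower number from compound 2 to compound 3 (0.19 log units; within the scatter), and not clearly beyond the scatter in either direction. Compound 3 is therefore estimated to give 6000 nM, with a range from 2500 nM to 15000 nM.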

Compound 3, half-maximal inhibitory concentration: 6300 nM
For compound 3 the middle estimate is 1.1-fold (0.02 log units) below the measured one; the measured number falls inside the stated range.
By their numbers in this assay, from the lowest: compounds 3, 1 and 2 (each within the scatter of the next).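

In this assay, for the compounds shown here, the exchange of trifluoromethyl for methoxy gives the first recorded step at this aromatic carbon, a 1.5-fold lower number from compound 2 to compound 3 (0.17 log units; within the scatter), so swapping a group of 4 heavy atoms and no hydrogen-bond acceptor for one of 2 heavy atoms and 1 hydrogen-bond acceptor does not separate the two compounds. The wider exchange of the whole aryl group on the amine nitrogen, 2-methoxyphenyl in place of 3-fluorophenyl, gives a 1.1-fold lower number from compound 1 to compound 3 (0.02 log units; within the scatter), which also does not separate its pair, so the three substituted phenyl groups shown cannot be told apart in this assay. No measurement at hand offers an explanation for this insensitivity.

On these data alone, it remains open whether a group of another kind on this ring, such as an amine, a carboxylic acid, a hydroxyl or a longer chain like ethoxy, would give a step beyond the scatter. Also open, as far as these compounds go, is whether any change to the shared core away from this aromatic ring would give a clearly stronger inhibitor than these three compounds.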